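The compounds below may be only part of what the source reports. "The series", "measured", "known", "first", "only" and "open" are said of these compounds alone.

In a functional assay on cells (Splenocyte, Mus musculus, strain BALB/c) for inhibition, read by MTT assay, with a stated time of 48 h (a lower number here means a stronger inhibitor, a higher number a weaker inhibitor), the three measured compounds gave these numbers:

Compound 1 `CO/C(=C\c1ccccc1)C(=O)Nc1ccc(Cl)cc1`: 17000 nM
Compound 2 `CO/C(=C\c1ccccc1)C(=O)Nc1ccc(C(C)C)cc1`: 3460 nM
Compound 3 `CO/C(=C\c1ccc(F)cc1)C(=O)Nc1ccc(Cl)cc1`: 9480 nM

Compound 3 stands second highest of the three. Its nearest neighbour is compound 1, whose number is higher but within the scatter, while compound 2 lies furthest, with a lower number beyond the scatter.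

Compound 4 `CO/C(=C\c1ccc(F)cc1)C(=O)Nc1ccc(C(C)C)cc1` differs from compound 3 in one place: isopropyl in place of chloro on an aromatic carbon. The same change has been measured once already, as a 4.9-fold lower number from compound 1 to compound 2 (0.69 log units; beyond the scatter), a modest step toward stronger inhibition. Carried over to compound 3, that step gives the expected 5.0-fold lower number from compound 3 to compound 4 (0.70 log units; beyond the scatter) in this assay. On that basis compound 4 is estimated at 1900 nM, with a range from 800 nM to 5000 nM.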

Compound 4, half-maximal inhibitory concentration: 4660 nM
The estimate for compound 4 lay 2.5-fold (0.39 log units) below the measured number, and the stated range covers the measured number.
By their numbers in this assay, from the lowest: compounds 2 and 4 (each within the scatter of the next); then compounds 3 and 1 (each within the scatter of the next).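

In this assay, isopropyl in place of chloro on an aromatic carbon lowers the number on a second core, giving a 2.0-fold lower number from compound 3 to compound 4 (0.31 log units; beyond the scatter), so the direction of this change holds for both pairs shown, and the two sizes do not clearly differ: the same change on two cores in this assay, a 4.9-fold lower number (0.69 log units; beyond the scatter) from compound 1 to compound 2 and a 2.0-fold lower number (0.31 log units; beyond the scatter) from compound 3 to compound 4, 2.4-fold (0.38 log units) apart, within the scatter of two such steps. Fluoro in place of hydrogen on an aromatic carbon, now read on the isopropyl core too, gives a 1.3-fold higher number from compound 2 to compound 4 (0.13 log units; within the scatter), and neither reading of this change leaves the scatter: the same change on two cores in this assay, a 1.8-fold lower number (0.25 log units; within the scatter) from compound 1 to compound 3 and a 1.3-fold higher number (0.13 log units; within the scatter) from compound 2 to compound 4, 2.4-fold (0.38 log units) apart, within the scatter of two such steps.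

The compounds shown leave open how an amine, a carboxylic acid or a longer chain would compare with isopropyl on that aromatic carbon.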